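Cyclohexyl in Place of Phenyl on the Amine Nitrogen

The source may hold more compounds than are shown below. What is called first, only, known or untested is meant among the compounds shown, and "the series" means these compounds.

Compound 1 `c1ccc(COc2ccc(OCCOCCNc3ccccc3)cc2)cc1`: > 100000 nM
Compound 2 `O=[N+]([O-])c1cccc(COc2ccc(OCCOCCNC3CCCC3)cc2)c1`: 15400 nM

In a functional assay on SK-OV-3 cells (Homo sapiens) for inhibition, read by CCK-8 assay, with a stated time of 70 h (a lower number here means a stronger inhibitor, a higher number a weaker inhibitor), compound 1 gives only a limit, > 100000 nM, so its place among the numbers is open; it stands at the limit of > 100000 nM in this assay, at which 1 of the 2 values shown sits. Compound 2 gives 15400 nM in this assay. Compound 3 `c1ccc(COc2ccc(OCCOCCNC3CCCCC3)cc2)cc1` is not yet measured. It differs from compound 1 by cyclohexyl in place of phenyl on an amine nitrogen. For the measured compounds named here, no measured step covers this change. He expects a step from compound 1 to compound 3 toward stronger inhibition, of size an at least 3.3-fold lower number from compound 1 to compound 3 (0.52 log units; beyond the scatter), beyond the scatter, though its true size cannot be read from a limit. He estimates for compound 3 a value of 30000 nM, between 8000 nM and 150000 nM.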

Compound 3, half-maximal inhibitory concentration: 7370 nM
Estimate against measurement, compound 3: 4.1-fold (0.61 log units) above, outside the stated range (below it).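

In this assay, cyclohexyl in place of phenyl on the amine nitrogen gives an at least 13-fold lower number from compound 1 to compound 3 (1.13 log units; beyond the scatter). This position therefore responds to an aromatic ring giving way to a non-aromatic one, although the counts of heavy atoms, donors and acceptors stay the same. Compound 1 stands only at a limit, and the true size of the step cannot be read from it: the limit of > 100000 nM in this assay, at which 1 of the 3 values shown sits.

From the compounds shown here alone, whether an open-chain group such as isopropyl or a piperidine ring would serve on this nitrogen remains open. Compound 2 carries a nitro group as well as cyclopentyl, so the effect of ring size alone also remains unresolved.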